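This account rests on a few compounds, and the source may have more. Where it says the series, first, only, none or still open, it means among the compounds named here.

Series notes. Compound 1 `Cc1ccccc1-c1nc(CN2CCC(C(=O)NCCCN3CCC(C)(C)CC3)CC2)c(C)o1` is the starting point for the present step. In an ADME assay on Huh7.5.1 cells (Homo sapiens) for cytotoxicity, read by ATP content, with a stated time of 48 h (a lower number here means that less compound is tolerated, a higher number that more compound is tolerated), compound 1 gives 10200 nM. Compound 2 `Cc1oc(-c2ccc(Cl)cc2)nc1CN1CCC(C(=O)NCCCN2C[C@H](C)C[C@H](C)C2)CC1` gives 11500 nM in this assay, and compound 3 `Cc1oc(-c2c(Cl)cccc2Br)nc1CN1CCC(C(=O)NCCCN2C[C@H](C)C[C@H](C)C2)CC1` gives 12200 nM. Compound 1 therefore holds the lowest of the three numbers, but its gap to compound 2 and its gap to compound 3 are both within the scatter, so the three measured compounds are not separated by this read-out.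

Going by the values given here, the only measured step, a 1.1-fold higher number from compound 2 to compound 3 (0.03 log units; within the scatter), changes the aromatic substituent on the shared core and leaves the amine end of the chain untouched.

Compound 4 `Cc1ccccc1-c1nc(CN2CCC(C(=O)NCCCCN3C[C@H](C)C[C@H](C)C3)CC2)c(C)o1` differs from compound 1 at that other end: (3,5-dimethylpiperidin-1-yl)methyl in place of 4,4-dimethylpiperidin-1-yl on a saturated chain carbon, three bonds along the chain from an amide-type nitrogen. Among the compounds with values here, no measured step touches the amine-bearing end of the chain, so the only guidance is the flat picture given by compound 1, compound 2 and compound 3, whose numbers all lie within the scatter of one another, together with the single aromatic step, which was itself within the scatter. On that basis no shift beyond the scatter is expected for compound 4 in this assay, and compound 4 is expected at 10500 nM, with a range of 5000 nM to 22000 nM. The step this estimate implies, a 1.0-fold higher number from compound 1 to compound 4 (0.01 log units; within the scatter), is expected to stay within the scatter.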

Compound 4, half-maximal cytotoxic concentration: 23100 nM
Compound 4: the middle estimate sits 2.2-fold (0.34 log units) below what was measured, and the stated range ends below it.
By their numbers in this assay, from the lowest: compounds 1, 2, 3 and 4 (each within the scatter of the next, the first and the last beyond it).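

Within this assay, the amine-bearing end of the chain responds where the aromatic substituent did not: the change from 4,4-dimethylpiperidin-1-yl to (3,5-dimethylpiperidin-1-yl)methyl gives a modest rise in the tolerated concentration (a 2.3-fold higher number from compound 1 to compound 4 (0.36 log units; beyond the scatter)), whereas the only aromatic step stayed within the scatter (a 1.1-fold higher number from compound 2 to compound 3 (0.03 log units; within the scatter)). This step joins two changes, since cutting one bond further out reads 2-(4,4-dimethylpiperidin-1-yl)ethyl to 3-(3,5-dimethylpiperidin-1-yl)propyl, so the chain and the ring's methyl pattern change together, and the ring gains 2 defined stereocentres. No measurement shown here explains the shift.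

The compounds shown leave open whether the shift follows the longer chain or the 3,5-dimethyl pattern, a question that 3-(4,4-dimethylpiperidin-1-yl)propyl on the same core would address directly. From the compounds shown here alone, how this assay reads for an unsubstituted piperidine, a morpholine or a 4-(3,5-dimethylpiperidin-1-yl)butyl chain at this position also remains open.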